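The source may hold more compounds than are shown below. What is called first, only, known or untested is meant among the compounds shown, and "the series" means these compounds.

- Compound 1 `COc1ccccc1/C=C/C(=O)OC/C=C/c1cc(OC)c(OC)cc1OC` gives 101 umol/kg in a functional assay on the whole organism (strain Kunming) with Mus musculus as the target, with a stated time of 0.5 h; on this read-out lower numbers stand for an effect already at smaller amounts and higher numbers for an effect only at larger amounts of compound
- Compound 2 `COc1cc(OC)c(OC)cc1/C=C/COC(=O)/C=C/c1ccccc1C(F)(F)F` gives 203 umol/kg in this assay
- Compound 3 `COc1cc(OC)c(OC)cc1/C=C/COC(=O)/C=C/c1ccccc1Cl` still awaits measurement

Within the data shown here, compound 2 has only one measured neighbour so far, and their two numbers lie within the usual scatter of each other. Compound 3 comes from compound 2 by a single change (chloro in place of trifluoromethyl on an aromatic carbon) with chloro in place of trifluoromethyl on an aromatic carbon, ortho to a large group. Among the measured compounds shown here, the one measured step that bears on this is a 2.0-fold higher number from compound 1 to compound 2 (0.30 log units; within the scatter) with trifluoromethyl in place of methoxy on the same aromatic carbon. From that small step alone, no change beyond the scatter is expected in this assay for the new swap. The expected step is a 1.5-fold lower number from compound 2 to compound 3 (0.16 log units; within the scatter) and this estimate rests on very little data. For compound 3 the estimated value is 140 umol/kg (expected range 65 umol/kg to 300 umol/kg).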

Compound 3, dose for half-maximal effect: 151 umol/kg
Compound 3: middle estimate off by 1.1-fold (0.03 log units), on the low side, and the stated range covers the measured number.
By their numbers in this assay, from the lowest: compounds 1, 3 and 2 (each within the scatter of the next).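

In this assay, chloro in place of trifluoromethyl on this aromatic carbon, ortho to a large group, gives a 1.3-fold lower number from compound 2 to compound 3 (0.13 log units; within the scatter) and chloro in place of methoxy gives a 1.5-fold higher number from compound 1 to compound 3 (0.17 log units; within the scatter). A third group has now been tried here, and swapping four heavy atoms for one did not move the number beyond the scatter, so methoxy, trifluoromethyl and chloro cannot be told apart at this carbon by this read-out. No measurement is available that would explain this.

Still open, as far as these compounds go, is whether a quite different group on this carbon, such as an amine, a carboxylic acid or a longer chain, would shift the number beyond the scatter. The compounds shown also leave open whether chloro would behave the same way on another carbon of this ring.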